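A few compounds are considered here, and "the series" means these few. Any claim that something is new, unique, unknown or untested is made for them only; others in the source may bear on it.

Working notes on the series in a functional assay on HT-29 cells (Homo sapiens) for cytotoxicity, read by sulforhodamine B assay; on this read-out higher numbers stand for weaker inhibition and lower numbers for stronger inhibition.

For the measured compounds named here, compound 3 `C=C1[C@@H](OC(C)=O)C[C@@H]2[C@](C)(COC=O)[C@H](OC(C)=O)CC[C@@]2(C)[C@@H]1C[C@@H](Nc1ccccc1C(=O)O)C1=CCOC1=O` gives 28700 nM and stands highest of the three numbers so far. Going by the values given here, its nearest neighbour is compound 1 `C=C1[C@@H](OC(C)=O)C[C@@H]2[C@](C)(COC=O)[C@H](OC(C)=O)CC[C@@]2(C)[C@@H]1C[C@@H](Nc1ccc(Br)cc1)C1=CCOC1=O`, which gives 13200 nM; the single change between them is covered by the step of a 2.2-fold higher number from compound 1 to compound 3 (0.34 log units; beyond the scatter). The furthest is compound 2 `C=C1[C@@H](OC(C)=O)C[C@@H]2[C@](C)(CO[Si](C)(C)C(C)(C)C)[C@H](OC(C)=O)CC[C@@]2(C)[C@@H]1C[C@@H](Nc1ccc(OC)cc1)C1=CCOC1=O`, which gives 5370 nM; compound 2 differs from compound 3 in more than one place, so its value is noted only for the spread it shows.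

Compound 4 `C=C1[C@@H](OC(C)=O)C[C@@H]2[C@](C)(COC=O)[C@H](OC(C)=O)CC[C@@]2(C)[C@@H]1C[C@@H](Nc1ccc(OC)c(OC)c1)C1=CCOC1=O` has not been measured. It differs from compound 3 as follows: 3,4-dimethoxyphenyl in place of 2-carboxyphenyl on an amine nitrogen. Among the compounds with values here, the only measured step that bears on this change is a 2.2-fold higher number from compound 1 to compound 3 (0.34 log units; beyond the scatter), read in reverse: replacing the 2-carboxyphenyl by another aryl group once gave a modestly lower number. Compound 2, carrying a methoxy-substituted phenyl on the same amine nitrogen, sits lowest, though its second difference keeps that from being a clean comparison.

A lower number is therefore expected for compound 4 in this assay, by a step of about a 3.2-fold lower number from compound 3 to compound 4 (0.50 log units; beyond the scatter). The estimate for compound 4 is 9000 nM, with a range from 3500 nM to 24000 nM.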

Compound 4, half-maximal inhibitory concentration: 42800 nM
Compound 4: the middle estimate sits 4.8-fold (0.68 log units) below what was measured, and the stated range ends below it.
By their numbers in this assay, from the lowest: compound 2; then compound 1; then compounds 3 and 4 (each within the scatter of the next).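

In this assay, 3,4-dimethoxyphenyl in place of 2-carboxyphenyl on the amine nitrogen gives a 1.5-fold higher number from compound 3 to compound 4 (0.17 log units; within the scatter), so two aryl groups with no substituent in common cannot be told apart at this position, and removing the carboxylic acid does not by itself bring the number down. Against 4-bromophenyl the same dimethoxy group gives a 3.2-fold higher number from compound 1 to compound 4 (0.51 log units; beyond the scatter), so compound 1 now stands apart from both compound 3 and compound 4, and the earlier step from 4-bromophenyl can no longer be read as a matter of the carboxylic acid alone. No measurement in hand offers a reason for either step.

The compounds shown leave open whether the bromine or the aryl ring as a whole sets the level of compound 1, which a plain phenyl or a 4-chlorophenyl group on the same core would help to separate. For the compounds shown here, also open is how much of the low number of compound 2 belongs to its 4-methoxyphenyl group and how much to its silyl ether, since the two differences are not separated so far.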